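The source may report more compounds than this note shows. Statements on the series, on what has been measured and on what is new or still open speak of the compounds shown alone.

Measured in an ADME assay on Caco-2 cells (Homo sapiens) for permeability, read by LC-MS, in the apical to basolateral direction, with a stated time of 60 min, at pH 6.5; on this read-out lower numbers stand for lower permeability and higher numbers for higher permeability:
Compound 1 `CCCC[C@@H](O)C(=O)N1C[C@H]2C[C@H]2[C@H]1C(=O)NCc1cc(Cl)ccc1-n1cnnn1`: 33 10^-6 cm/s
Compound 2 `CC1(C[C@@H](O)C(=O)N2C[C@H]3C[C@H]3[C@H]2C(=O)NCc2cc(Cl)ccc2-n2cnnn2)CC1`: 2.2 10^-6 cm/s

Of these two compounds, compound 2 has the lower number, and the gap to compound 1 lies beyond the usual scatter. Compound 3 `O=C(NCc1cc(Cl)ccc1-n1cnnn1)[C@@H]1[C@@H]2C[C@@H]2CN1C(=O)[C@H](O)c1ccccc1` has phenyl in place of (1-methylcyclopropyl)methyl on a saturated chain carbon bound to a carbonyl carbon and an oxygen on a saturated carbon.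

Among the compounds with values here, only one measured step bears on this change: a 15-fold lower number from compound 1 to compound 2 (1.18 log units; beyond the scatter). It is large, and it also came from changing the group on this chain, so a swap here can clearly move the number a long way. That single step says nothing about what phenyl will do, so any forecast is uncertain. A moderate rise is expected, and the estimated step is a 2.7-fold higher number from compound 2 to compound 3 (0.44 log units; beyond the scatter). For compound 3, the expected value is 6 10^-6 cm/s, with an estimated range of 1.5 10^-6 cm/s to 24 10^-6 cm/s.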

Compound 3, apparent permeability: 2.2 10^-6 cm/s
Beside the measured number, compound 3's estimate is 2.7-fold (0.44 log units) above it; measured number inside the range.
By their numbers in this assay, from the lowest: compounds 2 and 3 (each within the scatter of the next); then compound 1.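

Phenyl in place of (1-methylcyclopropyl)methyl on this saturated chain carbon leaves the number in place (no change at the digits printed from compound 2 to compound 3 (within the scatter)), as read in the assay (this assay). So the low number is not tied to (1-methylcyclopropyl)methyl, since a six-membered aromatic ring of carbon here gives the same reading as a three-membered non-aromatic ring, and phenyl in place of butyl gives a large step (a 15-fold lower number from compound 1 to compound 3 (1.18 log units; beyond the scatter)), leaving the butyl compound, compound 1, alone at the high end of these three. No measurement shown here accounts for this pattern.

Still open, from the compounds shown here alone, is whether a longer chain than butyl would stay near compound 1 or fall to the level of compound 2 and compound 3. An amine or a carboxylic acid at this position is equally untested by the compounds shown.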